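Methyl substitution on the saturated ring of the series

The compounds below may be only part of what the source reports. "The series", "measured", "known", "first", "only" and "open" are said of these compounds alone.

All values below come from a functional assay on A549 cells (Homo sapiens) for cytotoxicity, with a stated time of 60 h; on this read-out higher numbers stand for an effect only at larger amounts of compound and lower numbers for an effect already at smaller amounts.

Compound 1 `CCN(CC)C(=O)c1c(NC(=O)c2cccs2)sc2c1CCC2` gives 7100 nM
Compound 2 `CCN(CC)C(=O)c1c(NC(=O)c2cccs2)sc2c1CC(C)CC2` gives 1000 nM
Compound 3 `CCN(CC)C(=O)c1c(NC(=O)c2cccs2)sc2c1CC(C)C2` gives 7700 nM

Compound 4 `CCN(CC)C(=O)c1c(NC(=O)c2cccs2)sc2c1CC(C)(C)CC2` is not yet measured. The difference between the core of compound 1 and the core of compound 2 is not broken down here; compound 2 has the lowest number of the three measured, and the gaps to compound 1 and to compound 3 both lie beyond the scatter.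

From compound 1 to compound 3 the change is methyl in place of hydrogen on a saturated ring carbon and gives a 1.1-fold higher number from compound 1 to compound 3 (0.04 log units; within the scatter). From compound 2 to compound 4 the change is methyl in place of hydrogen on a saturated ring carbon, the same kind of change, but on a six-membered rather than a five-membered ring. Because a 1.1-fold higher number from compound 1 to compound 3 (0.04 log units; within the scatter) stayed within the scatter, a step of similar size, a 1.5-fold higher number from compound 2 to compound 4 (0.18 log units; within the scatter), is expected from compound 2 to compound 4 in this assay. For compound 4 a value near 1500 nM is estimated, between 500 nM and 5000 nM.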

Compound 4, half-maximal effective concentration: 6000 nM
Estimate against measurement, compound 4: 4.0-fold (0.60 log units) below; measured number above the stated range.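

In this assay, methyl in place of hydrogen on a saturated ring carbon gives a 6.0-fold higher number from compound 2 to compound 4 (0.78 log units; beyond the scatter). The size of this step does not carry over from one core to the other: the same change on two cores in this assay, a 1.1-fold higher number (0.04 log units; within the scatter) from compound 1 to compound 3 and a 6.0-fold higher number (0.78 log units; beyond the scatter) from compound 2 to compound 4, 5.5-fold (0.74 log units) apart, beyond the scatter of two such steps

The two pairs do not show whether the gap follows ring size or another difference between the cores, nor how the change behaves on any further core.

Still open, going by these compounds, is how a longer chain such as ethyl, an amine or a carboxylic acid on a saturated ring carbon would read on the core of compound 1 or the core of compound 2. On these data alone, whether any such group would keep the number near that of compound 2 also remains open.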